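The compounds below may be only part of what the source reports. "The series", "measured", "known", "first", "only" and "open" are said of these compounds alone.

Compound 1, `CC(C)(C)C(=O)N[C@@H]1[C@H](O)[C@@H](COP(=O)(O)OP(=O)(O)OP(=O)(O)O)O[C@H]1n1ccc(=O)[nH]c1=S`: 470 nM
Compound 2, `Nc1cn([C@@H]2O[C@H](COP(=O)(O)OP(=O)(O)OP(=O)(O)O)[C@@H](O)[C@H]2O)c(=O)[nH]c1=O`: 5600 nM

In an in vitro functional assay on 1321-N1 cells for agonist activity at P2Y purinoceptor 2 (Homo sapiens) (a higher number here means that more compound is needed for the effect, a lower number that less compound is needed), compound 1 gives 470 nM, while compound 2 gives 5600 nM, the highest of the two numbers and well beyond the scatter apart from compound 1. Compound 3, `[N-]=[N+]=Nc1cn([C@@H]2O[C@H](COP(=O)(O)OP(=O)(O)OP(=O)(O)O)[C@@H](O)[C@H]2O)c(=O)[nH]c1=O`, carries azido in place of amino on an aromatic carbon. Among the compounds with values here, no measured pair shows this change, so the size of the step is open; the swap keeps the triphosphate and the sugar intact, and a modest drop in the number is expected rather than a large one. Compound 3 is expected at 3000 nM, between 800 nM and 12000 nM, a step estimated as a 1.9-fold lower number from compound 2 to compound 3 (0.27 log units; within the scatter).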

Compound 3, half-maximal effective concentration: 1800 nM
Beside the measured number, compound 3's estimate is 1.7-fold (0.22 log units) above it, within the range that was stated.
By their numbers in this assay, from the lowest: compound 1; then compound 3; then compound 2.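

In this assay, replacing amino with azido on this aromatic carbon gives a 3.1-fold lower number from compound 2 to compound 3 (0.49 log units; beyond the scatter), a modest step. The position therefore tolerates a group of 3 heavy atoms with 0 hydrogen-bond donors, and the amino hydrogens are not needed for agonist activity at this level. No measurement here bears on why the number falls. On these data alone, how a bromine atom, an acetamide or a longer chain at the same position would compare remains open, as does whether a still lower number can be reached there.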